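Benzyl ring substituent change from compound 2 to compound 3

The source may hold more compounds than are shown below. What is called first, only, known or untested is meant among the compounds shown, and "the series" means these compounds.

Among the measured compounds shown here, compound 2 `COc1cccc(OC)c1OCCNCCOc1ccccc1OCc1ccc(Cl)cc1` gives 0.0316 nM in an assay on CHO cells for displacement of a labelled ligand from Alpha-1D adrenergic receptor (Homo sapiens) (on this read-out higher numbers stand for weaker inhibition and lower numbers for stronger inhibition), the lowest of the two numbers measured so far; compound 1 `COc1cccc(OC)c1OCCNCCOc1ccccc1OCc1ccccc1Cl` gives 0.251 nM, and the step of a 7.9-fold lower number from compound 1 to compound 2 (0.90 log units; beyond the scatter) is the only one recorded. Compound 3 `COc1cccc(OC)c1OCCNCCOc1ccccc1OCc1cccc(C)c1` differs from compound 2 by 3-methylphenyl in place of 4-chlorophenyl on a saturated chain carbon bound to an oxygen on an aromatic ring. For the measured compounds named here, no measured step covers this swap; the recorded step shows only that the substituent on this ring moves the number modestly. For compound 3 a modest rise in this assay is expected, a 3.2-fold higher number from compound 2 to compound 3 (0.50 log units; beyond the scatter). The estimate for compound 3 is 0.1 nM, within 0.03 nM to 0.4 nM.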

Compound 3, inhibition constant: 0.2 nM
Beside the measured number, compound 3's estimate is 2.0-fold (0.30 log units) below it; the range from low to high includes it.
By their numbers in this assay, from the lowest: compound 2; then compounds 3 and 1 (each within the scatter of the next).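

In this assay, 3-methylphenyl does not match 4-chlorophenyl at this position (a 6.3-fold higher number from compound 2 to compound 3 (0.80 log units; beyond the scatter)). It cannot be told apart from 2-chlorophenyl (a 1.3-fold lower number from compound 1 to compound 3 (0.10 log units; within the scatter)), so among these three compounds only compound 2 stands apart, and a low number is not tied to chlorine alone or to any one ring position. No evidence on the cause of this is at hand.

Compound 3 changes both the group and its ring position, so the contribution of each remains unresolved. A 4-methylphenyl or 3-chlorophenyl group would separate the two.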